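Benzyl substituent exchange on the amide-side chain

A few compounds are considered here, and "the series" means these few. Any claim that something is new, unique, unknown or untested is made for them only; others in the source may bear on it.

In a functional assay on CHO-K1 cells for antagonist activity at prostaglandin E2 receptor EP1 subtype (Homo sapiens), read by FLIPR and calcium flux (on this read-out lower numbers stand for stronger inhibition and higher numbers for weaker inhibition), the two measured compounds read:
compound 1 `CCc1ccccc1N(CC(=O)NCc1ccc(OC)c(OC)c1)S(=O)(=O)c1ccc(C)cc1` gives 282 nM
compound 2 `CCc1ccccc1N(CC(=O)NCc1ccc(Cl)cc1)S(=O)(=O)c1ccc(C)cc1` gives 11.5 nM

Compound 2 holds the lowest of the two numbers, set apart from compound 1 by the step of a 25-fold lower number from compound 1 to compound 2 (1.39 log units; beyond the scatter). Compound 3 `CCc1ccccc1N(CC(=O)NCc1ccccc1OC)S(=O)(=O)c1ccc(C)cc1` differs from compound 2 by 2-methoxyphenyl in place of 4-chlorophenyl on a saturated chain carbon bound to an amide-type nitrogen. Going by the values given here, only that one step bears on this change: moving from 3,4-dimethoxyphenyl to 4-chlorophenyl lowered the number strongly, so reversing toward a methoxy-bearing ring is expected to raise it in this assay, probably by less than the full distance, since compound 3 carries a single methoxy. Compound 3 is therefore estimated at 80 nM, within 20 nM to 320 nM. The expected step is a 7.0-fold higher number from compound 2 to compound 3 (0.84 log units; beyond the scatter).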

Compound 3, inhibition constant: 1070 nM
The estimate for compound 3 lay 13-fold (1.13 log units) below the measured number; measured number above the stated range.
By their numbers in this assay, from the lowest: compound 2; then compound 1; then compound 3.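

In this assay, the 2-methoxyphenyl group proved far less favourable than 4-chlorophenyl on a saturated chain carbon bound to an amide-type nitrogen, with a 93-fold higher number from compound 2 to compound 3 (1.97 log units; beyond the scatter). The single methoxy did not place compound 3 between the other two, as 2-methoxyphenyl in place of 3,4-dimethoxyphenyl gave a 3.8-fold higher number from compound 1 to compound 3 (0.58 log units; beyond the scatter), so across these compounds the number does not follow the count of methoxy groups. No measurement here accounts for this order. How 2-chlorobenzyl or 4-methoxybenzyl would read remains open, so the compounds shown do not separate the identity of the ring substituent from its placement.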